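Removing the bromo from a weak cytotoxic compound

The source may hold more compounds than are shown below. What is called first, only, known or untested is meant among the compounds shown, and "the series" means these compounds.

compound 1 `Cc1cn(-c2csc(Nc3ccc(Br)cc3)n2)c(C)n1`: 400 nM
compound 2 `COc1cccc(Nc2nc(-n3cc(C)nc3C)cs2)c1`: 22500 nM
compound 3 `Cc1nc2ccccc2n1-c1csc(Nc2cccc(Br)c2)n1`: 36000 nM

All three compounds were tested in a functional assay on RKO cells (Homo sapiens) for cytotoxicity, read by resazurin assay, with a stated time of 72 h; on this read-out lower numbers stand for stronger inhibition and higher numbers for weaker inhibition. There, compound 3 gives 36000 nM. Among the measured compounds shown here, that number lies within the scatter of the one for compound 2, so the two cannot be told apart. Both sit at the weak end of this small set, and compound 3 is clearly weaker than compound 1, which gives 400 nM.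

The next compound is compound 4 `Cc1nc2ccccc2n1-c1csc(Nc2ccccc2)n1`. It differs from compound 3 in one place: hydrogen in place of bromo on an aromatic carbon. In words, hydrogen takes the place of bromo on an aromatic carbon, turning 3-bromophenyl into phenyl.

For the measured compounds named here, no measured pair isolates this change, so any expectation is indirect. Compound 2 carries no bromo and still gives 22500 nM, close to the number for compound 3. Against this, compound 1 does carry a bromo and gives 400 nM, but it differs from compound 3 in more than one place. Losing the bromo is therefore expected to cause no step beyond the scatter, in either direction.

The expected result is a 1.2-fold lower number from compound 3 to compound 4 (0.08 log units; within the scatter). For compound 4 the estimated value is 30000 nM, with an expected range of 10000 nM to 80000 nM.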

Compound 4, half-maximal inhibitory concentration: 40000 nM
Estimate against measurement, compound 4: 1.3-fold (0.12 log units) below; measured number inside the range.
By their numbers in this assay, from the lowest: compound 1; then compounds 2, 3 and 4 (each within the scatter of the next).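

Turning 3-bromophenyl into phenyl gives a 1.1-fold higher number from compound 3 to compound 4 (0.05 log units; within the scatter) in this assay, and this is the first pair in the set that differs only at this place on an aromatic carbon. Among the compounds shown here, on this shared core, then, the bromo can be replaced by hydrogen with no readable shift in the number, something the earlier compounds could not show, as each of them differs from the others in more than one place. For the compounds shown here, no separate measurement bears on this result, so the pair records only that the number holds and offers no explanation for it.

Still open, as far as these compounds go, is whether any other group at this same place, such as an amine or a carboxylic acid, would move the number beyond the scatter, given that only bromo and hydrogen can be compared here on this core. Also open, from the compounds shown here alone, is whether the same change would be just as silent on the core of compound 1 , which gives 400 nM and also carries a bromo.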